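Morpholine Amide in Place of Primary Amide at Compound 1

This account rests on a few compounds, and the source may have more. Where it says the series, first, only, none or still open, it means among the compounds named here.

Compound 1, `NC(=O)/C=C/c1ccncc1-c1ccc2ccccc2c1`: > 10000 nM
Compound 2, `CNC(=O)/C=C/c1ccncc1-c1ccc2c(ccn2C)c1`: 8550 nM
Compound 3, `CNC(=O)/C=C/c1ccncc1-c1ccc2cc[nH]c2c1`: 7680 nM

Of the compounds shown here, three have been measured in a functional assay on MDA-MB-231 cells (Homo sapiens) for inhibition, read by sulforhodamine B assay, with a stated time of 72 h; a higher number here means a weaker inhibitor of growth, a lower number a stronger inhibitor of growth. Compound 1 gives only a limit, > 10000 nM, so its true number is not known (the limit of > 10000 nM in this assay, at which 1 of the 3 values shown sits). In this assay compound 2 gives 8550 nM, and compound 3 gives 7680 nM. For the measured compounds named here, no two measured compounds differ in one place, so no measured step is available. Compound 4, `O=C(/C=C/c1ccncc1-c1ccc2ccccc2c1)N1CCOCC1`, differs from compound 1 by morpholin-4-yl in place of amino on a carbonyl carbon. Since compound 1 sits at a limit, compound 4 is expected to remain a weak inhibitor. The step that the limit leaves unreadable from compound 1 to compound 4 is expected to be small, within the scatter, if it can be resolved at all. Compound 4 is estimated at 12000 nM, between 4000 nM and 40000 nM.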

Compound 4, concentration for 50% growth inhibition: 8980 nM
Beside the measured number, compound 4's estimate is 1.3-fold (0.13 log units) above it, within the range that was stated.
By their numbers in this assay, from the lowest: compounds 3, 2 and 4 (each within the scatter of the next). At a limit, above all of these: compound 1.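

In this assay, for the compounds shown here, compound 4 gives 8980 nM, the only number read on the core of compound 1, so morpholin-4-yl on this carbonyl carbon leaves growth inhibition measurable. The change gives an at least 1.1-fold lower number from compound 1 to compound 4 (0.04 log units; that floor lies within the scatter), so no gain can be claimed for it. Compound 1 has only a limit, so the true size of the step cannot be read: the limit of > 10000 nM in this assay, at which 1 of the 4 values shown sits.

From the compounds shown here alone, it remains open whether a piperazine ring or a dimethylamino group on the same carbonyl carbon would give a similar number. Also open, going by these compounds, is how morpholin-4-yl would read on the core of compound 2 or compound 3.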